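From cyclohexyl to 4-methoxyphenyl on an amine nitrogen

The source may hold more compounds than are shown below. What is called first, only, known or untested is meant among the compounds shown, and "the series" means these compounds.

In a functional assay on MGC-803 cells (Homo sapiens) for inhibition, read by sulforhodamine B assay (on this read-out lower numbers stand for stronger inhibition and higher numbers for weaker inhibition), compound 1 (`O=C1C(Nc2ccc(I)cc2)=CC(=O)c2c1nc1n2[C@H]2OC[C@@H](O)[C@H]2OC1`) gives 2150 nM and compound 2 (`O=C1C(Nc2ccccc2F)=CC(=O)c2c1nc1n2[C@H]2OC[C@@H](O)[C@H]2OC1`) gives 2000 nM as its value. Among the compounds with values here, the one measured step between them is a 1.1-fold lower number from compound 1 to compound 2 (0.03 log units; within the scatter) and shows no change beyond the usual spread. Compound 3 (`O=C1C=C(NC2CCCCC2)C(=O)c2c1nc1n2[C@H]2OC[C@@H](O)[C@H]2OC1`) is reported as > 8000 nM in this assay and that is a limit, not a number.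

Compound 4 (`COc1ccc(NC2=CC(=O)c3nc4n(c3C2=O)[C@H]2OC[C@@H](O)[C@H]2OC4)cc1`) differs from compound 3 by 4-methoxyphenyl in place of cyclohexyl on an amine nitrogen and keeps the shared core. Within the data shown here, no measured step covers this exchange directly. Among these three compounds, the two with a phenyl group on that nitrogen return numbers, while compound 3 with its cyclohexyl does not. Exchanging 4-iodophenyl for 2-fluorophenyl gave a 1.1-fold lower number from compound 1 to compound 2 (0.03 log units; within the scatter) as its step, so a third substituted phenyl is expected to land near compound 2 at 2000 nM in this assay. On these data alone, the expected change is an at least 3.2-fold lower number from compound 3 to compound 4 (0.50 log units; beyond the scatter) toward a lower number, though its true size stays open. Compound 4 is estimated at 2500 nM with an expected range of 1000 nM to 6500 nM in this assay for now.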

Compound 4, half-maximal inhibitory concentration: 1680 nM
For compound 4 the middle estimate is 1.5-fold (0.17 log units) above the measured one, within the range that was stated.
By their numbers in this assay, from the lowest: compounds 4, 2 and 1 (each within the scatter of the next). At a limit, above all of these: compound 3.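

In this assay, 4-methoxyphenyl in place of cyclohexyl on the amine nitrogen gives an at least 4.7-fold lower number from compound 3 to compound 4 (0.67 log units; beyond the scatter). This is the change at this position that lies beyond the scatter, whereas the exchange of one substituted phenyl for another in a 1.1-fold lower number from compound 1 to compound 2 (0.03 log units; within the scatter) did not move the number, and compound 4 now joins compound 1 and compound 2 as a third substituted phenyl whose value lies within the scatter of theirs. The full size of the step from cyclohexyl cannot be read, because compound 3 stands at a limit of the assay rather than at a number: the limit of > 8000 nM in this assay, at which 1 of the 4 values shown sits.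

The compounds shown leave open how an unsubstituted phenyl, a benzyl group or an open chain such as n-butyl on this nitrogen would read in this assay, and so whether the gap follows the phenyl ring itself or cyclohexyl alone. They also leave open whether a phenyl ring carrying an amine or a carboxylic acid would stay with compound 1, compound 2 and compound 4.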